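Swapping the aryl group on compound 2's propanamide chain

This account rests on a few compounds, and the source may have more. Where it says the series, first, only, none or still open, it means among the compounds named here.

Two compounds share one core and differ only in the group attached to the carbonyl carbon. Compound 1 `CC(C)C[C@H](N)c1cc(C(F)(F)F)ccc1N1CCN(C(=O)COc2ccc(O)cc2)CC1` gives 4600 nM in an assay on HEK293 cells for displacement of a labelled ligand from Melanocortin receptor 4 (Homo sapiens) (a higher number here means a weaker inhibitor, a lower number a stronger inhibitor), while compound 2 `COc1ccc(CC(C)C(=O)N2CCN(c3ccc(C(F)(F)F)cc3[C@@H](N)CC(C)C)CC2)cc1F` gives 200 nM. For the measured compounds named here, the single measured step, a 23-fold lower number from compound 1 to compound 2 (1.36 log units; beyond the scatter), is large, and compound 2 therefore stands with the lower of the two numbers. Compound 3 `CCOc1cccc(CC(C)C(=O)N2CCN(c3ccc(C(F)(F)F)cc3[C@@H](N)CC(C)C)CC2)c1` keeps the chain of compound 2 and changes only the ring at its end: 3-ethoxyphenyl in place of 3-fluoro-4-methoxyphenyl on a saturated chain carbon, two bonds along the chain from a carbonyl carbon. Going by the values given here, the one measured step bears on this region but changed both the chain and the ring together, so it gives no direct guide to a ring swap alone. A modest step in either direction, or none beyond the scatter, is expected. Compound 3 is estimated at 350 nM, between 90 nM and 1400 nM. This estimate means a step of a 1.8-fold higher number from compound 2 to compound 3 (0.24 log units; within the scatter) is expected.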

Compound 3, inhibition constant: 2200 nM
Compound 3: middle estimate off by 6.3-fold (0.80 log units), on the low side; the whole stated range lies below it.
By their numbers in this assay, from the lowest: compound 2; then compound 3; then compound 1.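

With the chain held fixed, the ring at its end proves to matter greatly in this assay: the change gives an 11-fold higher number from compound 2 to compound 3 (1.04 log units; beyond the scatter), even though both rings carry the same count of heavy atoms and hydrogen-bond acceptors. The new chain does not guarantee a strong result on its own, as the change from the (4-hydroxyphenoxy)methyl group to 1-(3-ethoxybenzyl)ethyl gives only a 2.1-fold lower number from compound 1 to compound 3 (0.32 log units; beyond the scatter). Nothing available explains why this ring swap has so large an effect.

The swap alters the fluorine, the ether chain and the ring positions at once, so it remains open which of these changes accounts for the step. Rings such as 3-methoxyphenyl, 4-methoxyphenyl or 3-fluorophenyl at the same place would separate these changes.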